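The source may hold more compounds than are shown below. What is called first, only, known or untested is meant among the compounds shown, and "the series" means these compounds.

The compounds share one core, shown in compound 1 `Cc1ccc(S/C(=C/c2ccc(N(C)C)cc2)C(=O)c2ccc(Cl)cc2)cc1`, and are followed in a functional assay on DU-145 cells (Homo sapiens) for inhibition, read by trypan blue exclusion, with a stated time of 96 h; on this read-out higher numbers stand for weaker inhibition of growth and lower numbers for stronger inhibition of growth. For compound 1 the read-out is only a limit of the assay: in this assay compound 1 gives > 100000 nM. Compound 2 `CN(C)c1ccc(/C=C(/Sc2ccc(Br)cc2)C(=O)c2ccc(Cl)cc2)cc1` carries bromo in place of methyl on an aromatic carbon. Its read-out is also a limit, as in this assay compound 2 gives > 100000 nM. Going by the values given here, the one measured step, a step that the two limits leave unreadable from compound 1 to compound 2, cannot therefore be read. Both measured values sit at the limit of > 100000 nM in this assay, at which 2 of the 2 values shown sit.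

Compound 3 `Cc1ccc(S/C(=C/c2cc(C)cc(C)c2)C(=O)c2ccc(Cl)cc2)cc1` differs from compound 1 as follows: 3,5-dimethylphenyl in place of 4-(dimethylamino)phenyl on a double-bonded chain carbon bound to a double-bonded chain carbon. Among the compounds with values here, no measured step bears on this change; the only step available concerns a different part of the core and is itself unreadable. On these data alone, with compound 1 at a limit in this assay, the starting point is unknown, so neither direction nor size can be read for the move from compound 1 to compound 3. The estimate for compound 3 in this assay is 100000 nM, with an expected range from 15000 nM to 500000 nM. That estimate means an expected step of a number no higher from compound 1 to compound 3 (the limit leaves the size open). It is expected that compound 3 would most likely again return only a limit.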

Compound 3, concentration for 50% growth inhibition: 50000 nM
Compound 3: the middle estimate sits 2.0-fold (0.30 log units) above what was measured; measured number inside the range.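

Compound 3 is the first compound in this assay whose read-out is a number and not a limit, while the other two values shown stay at the limit: the limit of > 100000 nM in this assay, at which 2 of the 3 values shown sit.

At this position, on a double-bonded chain carbon bound to a double-bonded chain carbon, 3,5-dimethylphenyl in place of 4-(dimethylamino)phenyl gives an at least 2.0-fold lower number from compound 1 to compound 3 (0.30 log units; that floor lies within the scatter). That floor is all that can be read, as compound 1 has only a limit, so the change is not shown to go beyond the usual scatter and its true size stays unknown.

The compounds shown leave open whether the number for compound 3 goes with the loss of the dimethylamino group or with the arrival of the two methyl groups, and a plain phenyl or a methoxy group at this position would help to separate the two. They also leave open what bromo in place of methyl on an aromatic carbon does, as that step cannot be read on the background of compound 1 and no compound shown carries bromo together with 3,5-dimethylphenyl.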